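The source may hold more compounds than are shown below. What is called first, only, known or untested is meant among the compounds shown, and "the series" means these compounds.

Series notes, shared core throughout. Among the compounds with values here, in a functional assay on A-375 cells (Homo sapiens) for cytotoxicity, read by MTT assay, with a stated time of 72 h (a lower number here means a stronger inhibitor, a higher number a weaker inhibitor), compound 1 `O=C1c2c[n+]([O-])c3ccccc3c2C(=O)c2c1c1ccccc1n2CCCCN1CCNCC1` gives 460 nM, and compound 2 `CCCCN1CCN(CCCCn2c3c(c4ccccc42)C(=O)c2c[n+]([O-])c4ccccc4c2C3=O)CC1` gives 2150 nM; the one measured step, a 4.7-fold higher number from compound 1 to compound 2 (0.67 log units; beyond the scatter), is butyl in place of hydrogen on an amine nitrogen in a ring. Compound 3 `CC1(C)OC[C@H](Cn2cc(Cn3c4c(c5ccccc53)C(=O)c3c[n+]([O-])c5ccccc5c3C4=O)nn2)O1` gives 180 nM and stands lowest of the three numbers, with compound 1 nearest and compound 2 furthest, both gaps beyond the scatter.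

Compound 4 `O=C1c2c[n+]([O-])c3ccccc3c2C(=O)c2c1c1ccccc1n2Cc1cn(C[C@@H](O)CO)nn1` differs from compound 3 only here: 1,2-dihydroxyethyl in place of 2,2-dimethyl-1,3-dioxolan-4-yl on a saturated chain carbon bound to an aromatic nitrogen. Within the data shown here, no measured step touches this kind of change, since the single step concerns an amine nitrogen in a ring rather than the chain carbon bound to an aromatic nitrogen. The expectation for compound 4 is therefore a step of a 1.6-fold higher number from compound 3 to compound 4 (0.19 log units; within the scatter) in this assay, within or close to the scatter, with weakening slightly more likely than strengthening. Compound 4 is estimated at 280 nM, range 110 nM to 700 nM.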

Compound 4, half-maximal inhibitory concentration: 140 nM
Estimate against measurement, compound 4: 2.0-fold (0.30 log units) above; low and high end bracket the measured number.
By their numbers in this assay, from the lowest: compounds 4 and 3 (each within the scatter of the next); then compound 1; then compound 2.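

In this assay 1,2-dihydroxyethyl in place of 2,2-dimethyl-1,3-dioxolan-4-yl gives a 1.3-fold lower number from compound 3 to compound 4 (0.11 log units; within the scatter) at this place, so the free diol and the ketal-closed ring cannot be told apart here. The diol also keeps the gain over the piperazine side chain, with a 3.3-fold lower number from compound 1 to compound 4 (0.52 log units; beyond the scatter) for 1-(2,3-dihydroxypropyl)-1H-1,2,3-triazol-4-yl in place of 3-(piperazin-1-yl)propyl. No measurement offered here explains either step. Open, from the compounds shown here alone, is what a carboxylic acid, a primary amine or a longer chain would give on this chain carbon, and whether the defined stereocentre matters.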